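The compounds below may be only part of what the source reports. "The series", "measured", "known", "first", "only" and "open" are said of these compounds alone.

Among the compounds with values here, in a functional assay on K562 cells (Homo sapiens) for inhibition, read by MTT assay, with a stated time of 48 h (a lower number here means a stronger inhibitor, a higher number a weaker inhibitor), three compounds sharing one core have numbers so far. Compound 2 `O=C(NC1CC1)c1cncc(-c2cn([C@@H]3CN[C@H](C(=O)Nc4ccc(Cl)c(C(F)(F)F)c4)C3)nn2)c1` gives 820 nM and holds the lowest of them, with compound 1 `CC(=O)Nc1ccc(-c2cn([C@@H]3CN[C@H](C(=O)Nc4ccc(Cl)c(C(F)(F)F)c4)C3)nn2)cn1` at 8980 nM and compound 3 `CCN(CC)C(=O)c1cncc(-c2cn([C@@H]3CN[C@H](C(=O)Nc4ccc(Cl)c(C(F)(F)F)c4)C3)nn2)c1` at 27600 nM on the higher side. Compound 4 `Nc1nc2ccc(-c3cn([C@@H]4CN[C@H](C(=O)Nc5ccc(Cl)c(C(F)(F)F)c5)C4)nn3)nc2s1` is still unmeasured. It differs from compound 2 by the change a group of 10 heavy atoms (6 carbon, 3 nitrogen, 1 sulfur; one five-membered aromatic ring with 2 hetero atoms, one six-membered aromatic ring with 1 hetero atom) in place of a group of 12 heavy atoms (9 carbon, 2 nitrogen, 1 oxygen; one three-membered non-aromatic ring of carbon only, one six-membered aromatic ring with 1 hetero atom), on an aromatic carbon on an aromatic carbon of a five-membered aromatic ring with 3 nitrogen. Within the data shown here, two measured steps bear on it, and both are large: an 11-fold lower number from compound 1 to compound 2 (1.04 log units; beyond the scatter) when the 5-(cyclopropylcarbamoyl)pyridin-3-yl group replaces the 6-acetamidopyridin-3-yl group, and a 34-fold higher number from compound 2 to compound 3 (1.53 log units; beyond the scatter) when diethylamino replaces cyclopropylamino. Compound 1, which also lacks the 5-(cyclopropylcarbamoyl)pyridin-3-yl group, stands at 8980 nM and serves as the nearest guide. A rise is therefore expected, and the estimate is a 6.1-fold higher number from compound 2 to compound 4 (0.79 log units; beyond the scatter). The expected value for compound 4 is 5000 nM with an estimated range (from 1200 nM to 20000 nM).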

Compound 4, half-maximal inhibitory concentration: 26200 nM
The estimate for compound 4 lay 5.2-fold (0.72 log units) below the measured number; measured number outside the range, above it.
By their numbers in this assay, from the lowest: compound 2; then compound 1; then compounds 4 and 3 (each within the scatter of the next).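

In this assay, the change to the group with a five-membered and a six-membered aromatic ring gave a 32-fold higher number from compound 2 to compound 4 (1.50 log units; beyond the scatter), a large loss that shows a second ring at this position did not retain the low number of compound 2. Against the other group lacking the cyclopropylcarbamoyl, the same group gave a 2.9-fold higher number from compound 1 to compound 4 (0.47 log units; beyond the scatter), a modest step, so at this position compound 2 remains below every other group shown. No measurement here accounts for these steps.

The compounds shown leave open how much of the low number of compound 2 rests on the cyclopropylamino on the carbonyl and how much on the pyridine that carries it. A cyclobutylamino or methylamino group on that carbonyl, or a plain phenyl in place of the pyridine, would separate these two contributions.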